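Replacing an Aryl Amide with an Ethenyl-Linked Aryl Amide

The source may hold more compounds than are shown below. What is called first, only, known or untested is meant among the compounds shown, and "the series" means these compounds.

Compound 1 `CN1[C@@H]2c3[nH]c4ccccc4c3C[C@H]1[C@H](C#N)N1[C@@H](CNC(=O)c3cccc(C(F)(F)F)c3)c3[nH]c4ccccc4c3C[C@@H]21` holds the lowest of the two numbers recorded in a functional assay on A2780 cells (Homo sapiens) for cytotoxicity, read by MTT assay, with a stated time of 72 h (a higher number here means a weaker inhibitor, a lower number a stronger inhibitor), where compound 1 gives 210 nM. Compound 2 `CN1[C@@H]2c3[nH]c4ccccc4c3C[C@H]1[C@H](C#N)N1[C@@H](CNC(=O)c3ccc(F)cc3)c3[nH]c4ccccc4c3C[C@@H]21` gives 250 nM in this assay, and the step of a 1.2-fold higher number from compound 1 to compound 2 (0.08 log units; within the scatter) keeps the pair indistinguishable. Compound 3 `CN1[C@@H]2c3[nH]c4ccccc4c3C[C@H]1[C@H](C#N)N1[C@@H](CNC(=O)/C=C/c3cccc(C(F)(F)F)c3)c3[nH]c4ccccc4c3C[C@@H]21` reaches only a limit of this assay, > 10000 nM. The steps of an at least 47-fold higher number from compound 1 to compound 3 (1.67 log units; beyond the scatter) and an at least 40-fold higher number from compound 2 to compound 3 (1.60 log units; beyond the scatter) are both large, and the limit of > 10000 nM in this assay, at which 1 of the 3 values shown sits, is where compound 3 sits.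

Compound 4 `CN1[C@@H]2c3[nH]c4ccccc4c3C[C@H]1[C@H](C#N)N1[C@@H](CNC(=O)/C=C/c3ccccc3)c3[nH]c4ccccc4c3C[C@@H]21` differs from compound 1 by 2-phenylethenyl in place of 3-(trifluoromethyl)phenyl on a carbonyl carbon. The change shares with the move to compound 3 the insertion of an ethenyl unit between the carbonyl carbon and the aromatic ring, and that move cost a large loss in this assay. Compound 4 is therefore expected to give 10000 nM in this assay, with a likely range from 2000 nM to 50000 nM. That estimate corresponds to an expected 48-fold higher number from compound 1 to compound 4 (1.68 log units; beyond the scatter), with a real chance that only a limit is reported.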

Compound 4, half-maximal inhibitory concentration: 770 nM
Beside the measured number, compound 4's estimate is 13-fold (1.11 log units) above it; measured number below the stated range.
By their numbers in this assay, from the lowest: compounds 1 and 2 (each within the scatter of the next); then compound 4. At a limit, above all of these: compound 3.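

The ethenyl unit alone does not remove activity in this assay: a 3.7-fold higher number from compound 1 to compound 4 (0.56 log units; beyond the scatter) and a 3.1-fold higher number from compound 2 to compound 4 (0.49 log units; beyond the scatter) are both modest. Compound 4 carries that unit without the large loss seen at compound 3. With the ethenyl unit in place, the ring substituent counts for far more, as an at least 12-fold lower number from compound 3 to compound 4 (1.11 log units; beyond the scatter) shows for hydrogen in place of trifluoromethyl, whereas the two directly attached aryl groups of compound 1 and compound 2 stay within the scatter of each other. The size of that step rests on a limit, the value of compound 3 being one: the limit of > 10000 nM in this assay, at which 1 of the 4 values shown sits.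

The compounds shown leave open whether a fluorine or a methoxy group on the ring of 2-phenylethenyl would be tolerated as hydrogen is or penalised as trifluoromethyl is. They also leave open whether a saturated 2-phenylethyl group would behave as 2-phenylethenyl does.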